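Amine chain length and buffer solubility in the series

The source may hold more compounds than are shown below. What is called first, only, known or untested is meant among the compounds shown, and "the series" means these compounds.

Measured so far:
compound 1 `CCCNC1CC(=O)OC1C(O)C(=O)NC(CC(C)C)C1Cc2cccc(O)c2C(=O)O1` — 1600 ug/mL
compound 2 `CNC1CC(=O)OC1C(O)C(=O)NC(CC(C)C)C1Cc2cccc(O)c2C(=O)O1` — 990 ug/mL

Solubility in a physicochemical assay for solubility, in phosphate buffer (a lower number here means a less soluble compound, a higher number a more soluble compound), is known for two compounds. In this assay compound 1 gives 1600 ug/mL and compound 2 gives 990 ug/mL. Compound 2 thus has the lowest of the two numbers shown, its nearest neighbour being compound 1, but the step between them is a 1.6-fold lower number from compound 1 to compound 2 (0.21 log units; within the scatter) and lies within the scatter, so the two compounds cannot be told apart on solubility.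

Compound 3 `CCNC1CC(=O)OC1C(O)C(=O)NC(CC(C)C)C1Cc2cccc(O)c2C(=O)O1` has not yet been measured. It differs from compound 2 by methyl in place of hydrogen on a saturated chain carbon bound to an amine nitrogen. Going by the values given here, the only measured step bearing on this change is a 1.6-fold lower number from compound 1 to compound 2 (0.21 log units; within the scatter), which took ethyl off the same saturated chain carbon and stayed within the scatter. Putting methyl back on that carbon is a smaller change in the opposite direction, so in this assay no step beyond the scatter is expected for compound 3, at most a slight rise toward compound 1. Compound 3 is therefore estimated at 1200 ug/mL, with a range from 700 ug/mL to 2100 ug/mL. For compound 3 this estimate means an expected step of a 1.2-fold higher number from compound 2 to compound 3 (0.08 log units; within the scatter).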

Compound 3, solubility: 11000 ug/mL
Compound 3: the middle estimate sits 9.2-fold (0.96 log units) below what was measured; measured number above the stated range.
By their numbers in this assay, from the lowest: compounds 2 and 1 (each within the scatter of the next); then compound 3.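

In this assay the step of an 11-fold higher number from compound 2 to compound 3 (1.05 log units; beyond the scatter) shows that a single methyl in place of hydrogen on a saturated chain carbon bound to an amine nitrogen can move the number well beyond the scatter, which the earlier pair never did. The change from the longer side, hydrogen in place of methyl on a saturated chain carbon, two bonds along the chain from an amine nitrogen, gives a 6.9-fold higher number from compound 1 to compound 3 (0.84 log units; beyond the scatter) and also lies beyond the scatter. Chain length at this position therefore does not track the number in one steady direction: compound 3, with its ethylamino group, stands above both the shorter chain of compound 2 and the longer chain of compound 1, and those two remain within the scatter of each other.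

On these data alone, it remains open whether the high number belongs to the ethylamino group alone or also appears with an isopropyl group, a cyclopropyl group or a butyl chain bound to the amine nitrogen. No supporting data bear on what lies behind the jump at compound 3.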